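Swapping the Amide Tail: What to Expect of Compound 3

A few compounds are considered here, and "the series" means these few. Any claim that something is new, unique, unknown or untested is made for them only; others in the source may bear on it.

Within the data shown here, compound 2 `CCOC(=O)C1=C(C)NC(C)=C(C(=O)OCC)C1c1ccc(OCC(=O)NNC(=O)c2ccc(C)cc2)cc1` carries the lower of the two numbers measured so far: in a functional assay on the whole organism (strain Wistar) for inhibition, with Rattus norvegicus as the target, read by paw edema, with stated times of 30 min and 1 h, at a dose of 20 mg/kg (on this read-out higher numbers stand for more inhibition at the one dose given (going by the name of the read-out) and lower numbers for less inhibition), compound 2 gives 35.9%, whereas compound 1 `CCOC(=O)C1=C(C)NC(C)=C(C(=O)OCC)C1c1ccc(OCC(=O)Nc2ccc(C)cc2)cc1` gives 55.1%. Among the measured compounds shown here, that gap is the only step measured, a number 19.2 percentage points lower from compound 1 to compound 2 (beyond the scatter). Compound 3 `CCOC(=O)C1=C(C)NC(C)=C(C(=O)OCC)C1c1ccc(OCC(=O)NN2C(=O)c3ccccc3C2=O)cc1` changes the same position once more: a group of 11 heavy atoms (8 carbon, 1 nitrogen, 2 oxygen; one five-membered non-aromatic ring with 1 hetero atom, one six-membered aromatic ring of carbon only) in place of a group of 10 heavy atoms (8 carbon, 1 nitrogen, 1 oxygen; one six-membered aromatic ring of carbon only), on an amide-type nitrogen. For the measured compounds named here, no measured step covers a swap of this kind, so the known step offers only a loose guide. A small step, within the usual scatter, is therefore expected, a number 1.9 percentage points lower from compound 2 to compound 3 (within the scatter). Compound 3 is expected to give about 34%, with a likely range from 20% to 50%.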

Compound 3, a percentage reported as inhibition, in the whole organism at one dose (the size of the read-out at that dose, not a potency): 42.3%
Compound 3: middle estimate off by 8.3 percentage points, on the low side; low and high end bracket the measured number.
By their numbers in this assay, from the lowest: compounds 2 and 3 (each within the scatter of the next); then compound 1.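

In this assay, the group with a five-membered non-aromatic ring and 0 hydrogen-bond donors stays level with ((4-methylphenyl)carbonyl)amino at this amide-type nitrogen (a number 6.4 percentage points higher from compound 2 to compound 3 (within the scatter)). Compound 3 still does not match the plain 4-methylphenyl group of compound 1 (a number 12.8 percentage points lower from compound 1 to compound 3 (beyond the scatter)), so both groups attached through a further nitrogen sit under compound 1. No measurement on hand explains these differences.

Open, as far as these compounds go, is whether an unsubstituted phenyl or a longer alkyl chain at this nitrogen would reach compound 1 or pass it.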